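This account rests on a few compounds, and the source may have more. Where it says the series, first, only, none or still open, it means among the compounds named here.

Compound 1 `O=C(Nc1ccccc1)c1cccc(/C=C2\CC(=O)N(c3ccccc3)C2=O)c1`, compound 2 `Cc1cccc(NC(=O)c2cccc(/C=C3\CC(=O)N(c4ccccc4)C3=O)c2)c1` and compound 3 `O=C(c1cccc(/C=C2\CC(=O)N(c3ccccc3)C2=O)c1)N1CCCC1`.

In an ADME assay on HCT-116 cells (Homo sapiens) for cytotoxicity, read by MTT assay, with a stated time of 72 h (on this read-out lower numbers stand for stronger inhibition and higher numbers for weaker inhibition), compound 1 gives only the limit of > 100000 nM. Compound 2 likewise gives only the limit of > 100000 nM. Compound 3 also gives only the limit of > 100000 nM. Among the compounds with values here, compound 3 thus stands at the limit of > 100000 nM in this assay, at which 3 of the 3 values shown sit, so none of the measured steps can be read: the change to compound 3 from compound 1 gives a step that the two limits leave unreadable from compound 1 to compound 3 and from compound 2 gives a step that the two limits leave unreadable from compound 2 to compound 3. Compound 4 `O=C(NCC1CCCCC1)c1cccc(/C=C2\CC(=O)N(c3ccccc3)C2=O)c1` carries (cyclohexylmethyl)amino in place of pyrrolidin-1-yl on a carbonyl carbon. The measured steps therefore set no size for this change; what is expected is a step that the limit leaves unreadable from compound 3 to compound 4, that is, nothing beyond the scatter. Compound 4 is accordingly estimated at 150000 nM, between 50000 nM and 500000 nM, most probably again reported as a limit.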

Compound 4, half-maximal inhibitory concentration: > 100000 nM
Compound 4 was reported as a limit (the forecaster's own chance of this, stated with the estimate: 85%); the middle value does not contradict the limit.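

Within the data shown here, compound 4 joins compound 1, compound 2 and compound 3 as a reported limit, so no step among them can be read: the limit of > 100000 nM in this assay, at which 4 of the 4 values shown sit.

In this assay the compounds shown leave open whether any change on the amide-type nitrogen alters the read-out at all.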